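An Acyl Change on the Shared Core of Compound 3

The source may hold more compounds than are shown below. What is called first, only, known or untested is meant among the compounds shown, and "the series" means these compounds.

Within the data shown here, compound 3 `Cc1cc(NC(=O)CC2CCCCC2)nn1Cc1cc(Cl)ccc1OCc1ccccc1` gives 6.31 nM in an assay on CHO-K1 cells for displacement of a labelled ligand from prostaglandin E2 receptor EP1 subtype (Homo sapiens) (on this read-out lower numbers stand for stronger inhibition and higher numbers for weaker inhibition), the lowest of the three numbers measured so far. Compound 1 `Cc1cc(C(=O)Nc2ccc(F)cc2)nn1Cc1cc(Cl)ccc1OCc1ccccc1` gives 79.4 nM in this assay and compound 2 `Cc1cc(C(=O)Nc2ccccn2)nn1Cc1cc(Cl)ccc1OCc1ccccc1` gives 126 nM; the steps of a 13-fold lower number from compound 1 to compound 3 (1.10 log units; beyond the scatter) and a 20-fold lower number from compound 2 to compound 3 (1.30 log units; beyond the scatter) were both large, whereas a 1.6-fold higher number from compound 1 to compound 2 (0.20 log units; within the scatter) stayed within the scatter. Compound 4 `Cc1cc(NC(=O)c2c(F)cccc2F)nn1Cc1cc(Cl)ccc1OCc1ccccc1` carries 2,6-difluorophenyl in place of cyclohexylmethyl on a carbonyl carbon. Among the measured compounds shown here, no measured step covers this change directly; the two large steps show only that the acylamino arrangement of compound 3 with its cyclohexylmethyl group beats the carbamoyl arrangements of compounds 1 and 2, which carry aromatic rings. An aromatic ring now enters on the acyl side, and a moderate rise in the number is expected, a 4.0-fold higher number from compound 3 to compound 4 (0.60 log units; beyond the scatter). Compound 4 is estimated at 25 nM, with a range from 6 nM to 100 nM.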

Compound 4, half-maximal inhibitory concentration: 12.6 nM
The estimate for compound 4 lay 2.0-fold (0.30 log units) above the measured number, within the range that was stated.
By their numbers in this assay, from the lowest: compounds 3 and 4 (each within the scatter of the next); then compounds 1 and 2 (each within the scatter of the next).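

In this assay, an aromatic ring on the acyl side costs nothing that can be read: a 2.0-fold higher number from compound 3 to compound 4 (0.30 log units; within the scatter) stays within the scatter, so 2,6-difluorophenyl and cyclohexylmethyl on this carbonyl carbon cannot be told apart. The acylamino arrangement keeps its advantage with an aromatic ring as well, with a 6.3-fold lower number from compound 1 to compound 4 (0.80 log units; beyond the scatter) and a 10-fold lower number from compound 2 to compound 4 (1.00 log units; beyond the scatter), so an aromatic ring alone does not set the higher numbers of compounds 1 and 2. Nothing at hand gives a reason for these steps. Still open, on these data alone, is whether both fluorines matter, which plain phenyl on the same carbonyl carbon would test. Also open, as far as these compounds go, is how this carbonyl carbon tolerates a longer chain or an amine.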